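Swapping Hydroxy for Amino in a Weakly Cytotoxic Series

The compounds below may be only part of what the source reports. "The series", "measured", "known", "first", "only" and "open" are said of these compounds alone.

Three compounds built on one shared core have been run through a functional assay on MDA-MB-231 cells (Homo sapiens) for cytotoxicity, read by MTT assay, with a stated time of 48 h; on this read-out higher numbers stand for weaker inhibition and lower numbers for stronger inhibition. Compound 1 `Fc1cccc(-c2nc(Nc3ccccc3)c3cc(F)ccc3n2)c1` gives 47800 nM. Compound 2 `Fc1cccc(-c2nc(Nc3ccccc3Br)c3cc(F)ccc3n2)c1`, carrying bromo in place of hydrogen on an aromatic carbon, returns only a limit of the assay, > 50000 nM. Compound 3 `Oc1cccc(Nc2nc(-c3cccc(F)c3)nc3ccc(F)cc23)c1` also returns only a limit, > 50000 nM. The step of an at least 1.0-fold higher number from compound 1 to compound 2 (0.01 log units; that floor lies within the scatter) and the step of an at least 1.0-fold higher number from compound 1 to compound 3 (0.01 log units; that floor lies within the scatter) are each known only through a floor that lies within the scatter, and the step that the two limits leave unreadable from compound 2 to compound 3 cannot be sized at all because both of its values rest on (the limit of > 50000 nM in this assay, at which 2 of the 3 values shown sit).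

Compound 3 thus stands at the weak edge of what the numbers show, with a limit rather than a value of its own. Compound 4 `Nc1cccc(Nc2nc(-c3cccc(F)c3)nc3ccc(F)cc23)c1` differs from it by amino in place of hydroxy on an aromatic carbon. Within the data shown here, no measured step covers this exchange; the two steps that are readable at all, bromo and hydroxy entering for hydrogen, were each bounded by a limit and so give no direction for it. In this assay the step that the limit leaves unreadable from compound 3 to compound 4 is therefore expected to stay within the scatter, most likely ending again at a limit. Compound 4 is estimated at about 55000 nM, ranging from 20000 nM to 150000 nM.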

Compound 4, half-maximal inhibitory concentration: > 50000 nM
Compound 4 gave a limit, no number; the forecaster's own chance of this, stated with the estimate: 60%; the middle value is on the limit's open side.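

In this assay compound 4 gives > 50000 nM, a limit of the assay and not a number, so amino on this aromatic carbon, like hydroxy before it, yields no value that can be placed on the scale. Among these compounds, the one readable step is an at least 1.0-fold higher number from compound 1 to compound 4 (0.01 log units; that floor lies within the scatter). The steps from compound 2 and from compound 3 to compound 4 cannot be read because both ends of each rest on the same limit: the limit of > 50000 nM in this assay, at which 3 of the 4 values shown sit.

Left open is whether a different group on this aromatic carbon, such as a methoxy group or a carboxylic acid, would return a number rather than a limit. On these data alone, compound 3 and compound 4 have no values of their own, so how hydroxy and amino compare at this place also remains open.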